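Isoquinolinyl amide replacing benzofuranyl in a cytotoxicity series

The source may hold more compounds than are shown below. What is called first, only, known or untested is meant among the compounds shown, and "the series" means these compounds.

The shared core carries a tetradecyl amide and a threonine-derived hydroxyl, with an aromatic amide varied on the carbonyl carbon. Compound 1 `CCCCCCCCCCCCCCNC(=O)[C@@H](NC(=O)c1ccccc1)[C@@H](C)O` bears a phenyl there; in a functional assay on SiHa cells (Homo sapiens) for cytotoxicity, read by MTT assay, with a stated time of 48 h (on this read-out higher numbers stand for weaker inhibition and lower numbers for stronger inhibition), compound 1 gives only a limit of > 200000 nM, not a number. Going by the values given here, compound 2 `CCCCCCCCCCCCCCNC(=O)[C@@H](NC(=O)c1cc2ccccc2o1)[C@@H](C)O` bears a 1-benzofuran-2-yl, and in this assay compound 2 gives 14200 nM, the only number yet available, so it stands as the sole reference point. The step of an at least 14-fold lower number from compound 1 to compound 2 (1.14 log units; beyond the scatter) rests on that limit (the limit of > 200000 nM in this assay, at which 1 of the 2 values shown sits). Compound 3 `CCCCCCCCCCCCCCNC(=O)[C@@H](NC(=O)c1nccc2ccccc12)[C@@H](C)O` carries the change (isoquinolin-1-yl in place of 1-benzofuran-2-yl on a carbonyl carbon). Among the compounds with values here, only the single measured step bears on this change, and it concerns a different exchange, so for compound 3 a step within the scatter of compound 2 is expected, a 1.2-fold lower number from compound 2 to compound 3 (0.07 log units; within the scatter). Compound 3 is therefore estimated at 12000 nM, within 4000 nM to 40000 nM.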

Compound 3, half-maximal inhibitory concentration: 21600 nM
The estimate for compound 3 lay 1.8-fold (0.26 log units) below the measured number, and the stated range covers the measured number.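

In this assay, isoquinolin-1-yl in place of 1-benzofuran-2-yl on the carbonyl carbon gives a 1.5-fold higher number from compound 2 to compound 3 (0.18 log units; within the scatter), so the two groups cannot be told apart on this read-out. An oxygen-containing five-membered aromatic ring can thus give way to a nitrogen-containing six-membered aromatic ring at this place without a change beyond the scatter. The advantage over the phenyl of compound 1 is therefore not confined to 1-benzofuran-2-yl, as isoquinolin-1-yl also gives an at least 9.2-fold lower number from compound 1 to compound 3 (0.96 log units; beyond the scatter), although the true size of this step cannot be read from a limit: the limit of > 200000 nM in this assay, at which 1 of the 3 values shown sits.

On these data alone, whether a naphthalen-2-yl group, with carbon only in its rings, would read like these two groups remains open. So does the effect of a decyl chain in place of the tetradecyl chain on the amide.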